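A few compounds are considered here, and "the series" means these few. Any claim that something is new, unique, unknown or untested is made for them only; others in the source may bear on it.

Working notes on an ADME assay on MT4 cells (Homo sapiens) for cytotoxicity, read by MTT assay; a lower number here means that less compound is tolerated, a higher number that more compound is tolerated. Among the compounds with values here, compound 1 (`O=C1c2ccccc2C(=O)N1CCOC(=S)N(C(=O)c1ccc([N+](=O)[O-])cc1Cl)c1ccc(Cl)cc1`) gives 19000 nM, and compound 2 (`O=C1c2ccccc2C(=O)N1CCOC(=S)N(C(=O)c1cccc2ccccc12)c1ccc(Cl)cc1`) gives 6000 nM, the lower of the two numbers so far. Compound 3 (`O=C1c2ccccc2C(=O)N1CCOC(=S)N(C(=O)c1cc2ccccc2s1)c1ccc(Cl)cc1`) keeps the rest of compound 2 and changes one group: 1-benzothiophen-2-yl in place of naphthalen-1-yl on a carbonyl carbon. In short, 1-benzothiophen-2-yl stands in place of naphthalen-1-yl on a carbonyl carbon. Within the data shown here, only one measured step bears on this, a 3.2-fold lower number from compound 1 to compound 2 (0.50 log units; beyond the scatter), a modest change at the same carbonyl carbon. Among the measured compounds shown here, it shows that this place can shift the number, but it involved a different pair of groups, and no measurement yet covers 1-benzothiophen-2-yl. On these data alone, the direction therefore stays open, and no step beyond the scatter is expected: a 1.2-fold higher number from compound 2 to compound 3 (0.07 log units; within the scatter) is the estimated move. For compound 3 the estimated value is 7000 nM, with an expected range of 2500 nM to 19000 nM.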

Compound 3, half-maximal cytotoxic concentration: 56000 nM
For compound 3 the middle estimate is 8.0-fold (0.90 log units) below the measured one; the measured number lies above the stated range.
By their numbers in this assay, from the lowest: compound 2; then compound 1; then compound 3.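

In this assay, the change of group on the carbonyl carbon gives a 9.3-fold higher number from compound 2 to compound 3 (0.97 log units; beyond the scatter), which shows that this place can also move the number upward and that two groups with aromatic rings are not interchangeable here. Against the third group, the change gives a 2.9-fold higher number from compound 1 to compound 3 (0.47 log units; beyond the scatter), so compound 3 holds the highest number of the three, with compound 1 in the middle. Nothing available here explains this step.

Whether the step follows the sulfur or the five-membered ring stays open, as 1-benzofuran-2-yl, with oxygen in place of sulfur, and naphthalen-2-yl are not among the compounds shown. Also open, on these data alone, is how a thiophen-2-yl group or a simple alkyl chain on the same carbonyl carbon would read.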